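Replacing methyl with nitro on the shared core

The source may hold more compounds than are shown below. What is called first, only, known or untested is meant among the compounds shown, and "the series" means these compounds.

Compound 1 `CCOC(=O)C(=O)Nc1cccc(N(C)C)c1C#N` gives 0.2 mg/kg
Compound 2 `CCOC(=O)C(=O)Nc1cccc(NC)c1C#N` gives 0.2 mg/kg
Compound 3 `CCOC(=O)C(=O)Nc1cccc(C)c1C#N` gives 5.3 mg/kg

In a functional assay on the whole organism with Rattus norvegicus as the target (a higher number here means that more compound is needed for the effect, a lower number that less compound is needed), compound 3 stands highest of the three at 5.3 mg/kg, so it needs more compound than either of the others. The two amino-bearing compounds cannot be told apart, with no change at the digits printed from compound 1 to compound 2 (within the scatter).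

The next compound, compound 4 `CCOC(=O)C(=O)Nc1cccc([N+](=O)[O-])c1C#N`, keeps the core of compound 3 and exchanges one group, nitro in place of methyl on an aromatic carbon. The new group sits ortho to a cyano group.

The closest evidence comes from two large steps at this kind of substitution, a 27-fold higher number from compound 1 to compound 3 (1.42 log units; beyond the scatter) and a 27-fold higher number from compound 2 to compound 3 (1.42 log units; beyond the scatter). Both show that the group in this place can move the dose considerably, and that methyl gives the higher number of those tried. Among the measured compounds shown here, neither step involves nitro, however, and no measured compound carries it, so they fix neither the size nor the direction with any certainty.

A moderate move towards a lower number is therefore expected, well short of those two steps, and the expected step is a 2.7-fold lower number from compound 3 to compound 4 (0.42 log units; beyond the scatter). For compound 4 the estimate in this assay is 2 mg/kg, with an expected range from 0.4 mg/kg to 8 mg/kg.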

Compound 4, dose for half-maximal effect: 0.4 mg/kg
Compound 4: middle estimate off by 5.0-fold (0.70 log units), on the high side, within the range that was stated.
By their numbers in this assay, from the lowest: compounds 1, 2 and 4 (each within the scatter of the next); then compound 3.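

In this assay the exchange of methyl for nitro on this aromatic carbon is a large step (a 13-fold lower number from compound 3 to compound 4 (1.12 log units; beyond the scatter)), which shows that a low dose at this position does not depend on an amino group. Nitro stands level with both amino groups (a 2.0-fold higher number from compound 2 to compound 4 (0.30 log units; within the scatter); a 2.0-fold higher number from compound 1 to compound 4 (0.30 log units; within the scatter)), so of the four groups seen at this place, only the methyl of compound 3 stands apart, while nitro, methylamino and dimethylamino cannot be told apart despite their different atoms. No measurement is available that would explain why these three groups give such similar doses or why methyl differs from them.

The compounds shown leave open whether other groups on this carbon, such as a plain amine, a methoxy group, a carboxylic acid or a longer chain, would join the three low-dose compounds or sit nearer to compound 3. They also leave open whether nitro would hold this standing without the cyano group to which it is ortho, since all four compounds carry that group and the same group of 8 heavy atoms.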